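The source may hold more compounds than are shown below. What is called first, only, known or untested is meant among the compounds shown, and "the series" means these compounds.

In a functional assay on A549 cells (Homo sapiens) for antiproliferative activity, read by sulforhodamine B assay, with a stated time of 48 h (on this read-out higher numbers stand for weaker inhibition and lower numbers for stronger inhibition), compound 1 (`COc1ccc(C[C@@H](O)/C=C/C=C/C(=O)N2CCCCC2)cc1OC`) gives 16400 nM while compound 2 (`COc1ccc(C[C@@H](O)/C=C/C=C/C(=O)N2CCN(c3ccccc3)CC2)cc1OC`) gives 14200 nM and compound 3 (`COc1ccc(C[C@@H](O)/C=C/C=C/C(=O)NCc2cc(OC)c(OC)c(OC)c2)cc1OC`) gives 19200 nM as its reading. These compounds share one core and differ in the group on the carbonyl carbon. Compound 1 stands among close neighbours: all three numbers lie within the usual scatter of repeated measurements, so they cannot be put in a reliable order.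

Compound 4 (`COc1ccc(C[C@@H](O)/C=C/C=C/C(=O)N2CCCC2)cc1OC`) has not been measured yet. It carries pyrrolidin-1-yl in place of piperidin-1-yl on a carbonyl carbon. Among the compounds with values here, no measured pair isolates a single change, so the data offer no direct guide to the size of this one. Still, the groups in compound 2 (14200 nM) and compound 3 (19200 nM) differ far more from the group in compound 1 (16400 nM) than pyrrolidin-1-yl does, and those numbers remain within the scatter. No step beyond the scatter is therefore expected in this assay for this swap. The estimated step of a 1.1-fold lower number from compound 1 to compound 4 (0.04 log units; within the scatter) is small and stays within the scatter. For compound 4 the expected value is 15000 nM with an estimated range from 8000 nM to 28000 nM when the measurement arrives.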

Compound 4, half-maximal inhibitory concentration: 24400 nM
For compound 4 the middle estimate is 1.6-fold (0.21 log units) below the measured one, and the stated range covers the measured number.
By their numbers in this assay, from the lowest: compounds 2, 1, 3 and 4 (each within the scatter of the next).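

Compound 4 gives the series its first pair that differs in one place only, so the size of the ring on the carbonyl carbon can now be judged by itself. In this assay the swap of piperidin-1-yl for pyrrolidin-1-yl gives a 1.5-fold higher number from compound 1 to compound 4 (0.17 log units; within the scatter) and so shows that this change, which takes one carbon out of the ring, does not shift the reading by more than repeated measurements of the same compound may differ. No measured information is available that would explain the reading of either compound.

On these data alone, what stays open is whether a different ring or group on the carbonyl carbon, such as the seven-membered azepan-1-yl, morpholin-4-yl with its ring oxygen, or a simple dimethylamino group, would move the reading beyond the scatter. The compounds shown also leave open whether the swap from piperidin-1-yl to pyrrolidin-1-yl would stay as small on a different core, or in cells other than the one line tested here.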